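Oxalyl Ester Exchanged for Azidoacetyl on the Shared Core

The source may hold more compounds than are shown below. What is called first, only, known or untested is meant among the compounds shown, and "the series" means these compounds.

Of the compounds shown here, two built on one shared core have been measured in a functional assay on NCI-H460 cells (Homo sapiens); on this read-out lower numbers stand for an effect already at smaller amounts and higher numbers for an effect only at larger amounts of compound. Compound 1 `COc1cc(C2OC(c3ccc(N(C)C)cc3)=NN2C=O)cc(OC)c1OC` gives 0.12 uM. Within the data shown here, compound 2 `CCOC(=O)C(=O)N1N=C(c2ccc(N(C)C)cc2)OC1c1cc(OC)c(OC)c(OC)c1` gives 33 uM, the highest of the two numbers, and the step of a 280-fold higher number from compound 1 to compound 2 (2.44 log units; beyond the scatter) separates it from its only neighbour. Compound 3 `COc1cc(C2OC(c3ccc(N(C)C)cc3)=NN2C(=O)CN=[N+]=[N-])cc(OC)c1OC` differs from compound 2 by azidomethyl in place of ethoxycarbonyl on a carbonyl carbon. Among the measured compounds shown here, the sole measured step that bears on this change is a 280-fold higher number from compound 1 to compound 2 (2.44 log units; beyond the scatter), in which the same ethoxycarbonyl that now leaves had entered in place of hydrogen. Because a 280-fold higher number from compound 1 to compound 2 (2.44 log units; beyond the scatter) is large, removing the ethoxycarbonyl is expected to bring the number down, although the azidomethyl that enters keeps compound 3 from being a return to compound 1, so a step of intermediate size is expected, a 17-fold lower number from compound 2 to compound 3 (1.22 log units; beyond the scatter). Compound 3 is accordingly estimated at 2 uM in this assay, with a range from 0.3 uM to 15 uM.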

Compound 3, concentration for half-maximal effect: 0.53 uM
Estimate against measurement, compound 3: 3.8-fold (0.58 log units) above; the range from low to high includes it.
By their numbers in this assay, from the lowest: compound 1; then compound 3; then compound 2.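

In this assay the place on a carbonyl carbon has now carried three different groups, and the exchange of ethoxycarbonyl for azidomethyl gives a 62-fold lower number from compound 2 to compound 3 (1.79 log units; beyond the scatter) so the large rise seen with ethoxycarbonyl does not follow from simply putting a larger group than hydrogen there. Azidomethyl in place of hydrogen gives only a 4.4-fold higher number from compound 1 to compound 3 (0.65 log units; beyond the scatter) which is modest but still beyond the scatter, so compound 1 keeps the lowest number of the three. The data offer no measured explanation for why these two groups behave so differently at this place.

The compounds shown leave open whether a plain methyl, an aminomethyl or a longer chain would stay close to compound 3 or move towards compound 2. They also leave open how a carboxylic acid in place of the ethyl ester would read.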